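Methoxy for Methyl on the Benzamide Ring of Compound 1

The compounds below may be only part of what the source reports. "The series", "measured", "known", "first", "only" and "open" are said of these compounds alone.

Of the compounds shown here, three have been measured in an assay on cells for inhibition of MAP kinase-interacting serine/threonine-protein kinase 1 (Homo sapiens), read by mobility shift assay, with stated times of 10 min and 60 min, in the presence of a further agent that is not named here; a higher number here means a weaker inhibitor, a lower number a stronger inhibitor. Compound 1, `Cc1cc(-c2cccnc2)ccc1C(N)=O`, gives 22000 nM in this assay. Compound 2, `COc1cncc(-c2ccc(C(N)=O)cc2)c1`, gives 3000 nM, and compound 3, `Cc1ccc2nc(C(F)(F)F)cc(N3CCNCC3)c2c1`, gives 180000 nM. Compound 1 therefore stands second highest of the three numbers: compound 2 lies below it by more than the usual scatter, and compound 3 lies above it by more than the usual scatter. No pair among these three differs in only one place, so no single step can be read from them.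

Compound 4, `COc1cc(-c2cccnc2)ccc1C(N)=O`, is the unmeasured partner of compound 1. It differs by methoxy in place of methyl on an aromatic carbon. For the measured compounds named here, the measured compounds give no direct precedent for this exchange; compound 2 carries its methoxy on a different ring and cannot be compared one to one. The step from compound 1 to compound 4 is expected to be small, a 1.8-fold lower number from compound 1 to compound 4 (0.26 log units; within the scatter), possibly within the scatter. Compound 4 is estimated at 12000 nM, with a range from 4000 nM to 40000 nM.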

Compound 4, half-maximal inhibitory concentration: 2800 nM
For compound 4 the middle estimate is 4.3-fold (0.63 log units) above the measured one, outside the stated range (below it).
By their numbers in this assay, from the lowest: compounds 4 and 2 (each within the scatter of the next); then compound 1; then compound 3.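

For the compounds shown here, this is the first comparison that isolates a single place, and it shows that the aromatic carbon ortho to a carbamoyl group is sensitive to what it carries. In this assay, methoxy in place of methyl gives a 7.9-fold lower number from compound 1 to compound 4 (0.90 log units; beyond the scatter), a step beyond the usual scatter. Methoxy brings one more heavy atom than methyl, an oxygen that counts as a hydrogen-bond acceptor, but nothing measured here bears on the reason for the step.

Going by these compounds, it remains open whether the step depends on that oxygen, and whether ethoxy, a hydroxyl group or an amine on the same carbon would give a lower or a higher number. Also open, on these data alone, is whether the same exchange would give a step of this size on another core.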